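Extending the Ethyl Arm of Compound 2 Toward a Basic Tail

The source may report more compounds than this note shows. Statements on the series, on what has been measured and on what is new or still open speak of the compounds shown alone.

Two compounds share one core and differ only in the amino group on the aromatic carbon. Compound 1 `CC(C)CCN(CCC(C)C)c1ccc(C(=O)N2CCc3ccc(OS(N)(=O)=O)cc3C2)cc1` carries a diisopentylamino group there, compound 2 `CCN(Cc1ccccc1)c1ccc(C(=O)N2CCc3ccc(OS(N)(=O)=O)cc3C2)cc1` a benzyl(ethyl)amino group. In an assay on HEK293 cells for inhibition of Steryl-sulfatase (Homo sapiens), tested at 0.1 uM (on this read-out higher numbers stand for a stronger effect at the one concentration tested and lower numbers for a weaker effect), compound 1 gives 47%, and compound 2 gives 66.9%. That single step, a number 19.9 percentage points higher from compound 1 to compound 2 (beyond the scatter), places compound 2 highest of the two numbers recorded so far.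

Compound 3 `CN(C)CCCN(Cc1ccccc1)c1ccc(C(=O)N2CCc3ccc(OS(N)(=O)=O)cc3C2)cc1` differs from compound 2 by (dimethylamino)methyl in place of hydrogen on a saturated chain carbon, two bonds along the chain from a nitrogen on an aromatic ring. Among the measured compounds shown here, no measured step bears directly on this change: the only step known swapped both groups on the ring nitrogen at once, and nothing shows what happens when the ethyl arm alone is lengthened into a 3-(dimethylamino)propyl chain. With no pointer in either direction, the expectation is a step of no size beyond the usual scatter, a number 6.9 percentage points lower from compound 2 to compound 3 (within the scatter), in this assay. Compound 3 is therefore estimated at 60%, with a range from 40% to 78%.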

Compound 3, a percentage reported as inhibition, at one concentration (the size of the read-out at that concentration, not a potency): 16.2%
The estimate for compound 3 lay 43.8 percentage points above the measured number; the whole stated range lies above it.
By their numbers in this assay, from the lowest: compound 3; then compound 1; then compound 2.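

Changing only the ethyl arm into a 3-(dimethylamino)propyl chain, with the benzyl group and the shared core left untouched, gives a number 50.7 percentage points lower from compound 2 to compound 3 (beyond the scatter) in this assay. Among the compounds shown here, the earlier step, a number 19.9 percentage points higher from compound 1 to compound 2 (beyond the scatter), replaced both groups on the nitrogen at once, so this is the first reading of one arm on its own, and it shows that the read-out is highly sensitive to what this arm carries. Nothing measured here speaks to the cause of this drop.

The compounds shown leave open whether the drop goes with the greater chain length itself or with the dimethylamino group at its end: a plain propyl or butyl arm would bear on the first question, and a 3-hydroxypropyl arm on the second. Also open, from the compounds shown here alone, is whether a shorter 2-(dimethylamino)ethyl arm, or a chain ending in a ring amine such as morpholine, would follow compound 3 or stay closer to compound 2.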